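The source may report more compounds than this note shows. Statements on the series, on what has been measured and on what is new or still open speak of the compounds shown alone.

Compound 1 `Cc1nc(C(NC(=O)C(=O)Nc2ccc(F)c(F)c2)C2CCCCN2)sc1CO` — in an ADME assay on TZM-b1 cells (Homo sapiens) for cytotoxicity, read by XTT assay, with a stated time of 3 days (on this read-out higher numbers stand for lower toxicity in this test and lower numbers for higher toxicity in this test), compound 1 gives only a limit of the assay, > 87000 nM.
Compound 2 `Cc1nc(C(NC(=O)C(=O)Nc2ccc(C(F)(F)F)cc2)C2CCCCN2)sc1CO` — in this assay compound 2 gives only a limit, > 75500 nM.
Compound 3 `Cc1ccc(NC(=O)C(=O)NC(c2nc(C)c(CO)s2)C2CCCCN2)c(F)c1` — in this assay compound 3 gives only a limit, > 88000 nM.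

Compound 1 thus stands at a limit rather than at a number in this assay, and the two other values shown are limits as well. The change from compound 1 to compound 4 `Cc1nc(C(NC(=O)C(=O)Nc2ccc(F)c(F)c2)C2CCCCN2)sc1CCO` is hydroxymethyl in place of hydroxy on a saturated chain carbon bound to an aromatic carbon. Among the measured compounds shown here, no measured step touches this part of the shared core; the steps that exist all exchange the aryl group on the amide-type nitrogen: a step that the two limits leave unreadable from compound 1 to compound 2, a step that the two limits leave unreadable from compound 1 to compound 3 and a step that the two limits leave unreadable from compound 2 to compound 3, none of them readable in size. Compound 4 is accordingly expected to sit at a limit too, with a step that the limit leaves unreadable from compound 1 to compound 4 expected to be none beyond the scatter. For compound 4 the estimate in this assay is 90000 nM, ranging from 40000 nM to 200000 nM.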

Compound 4, half-maximal cytotoxic concentration: > 78200 nM
Compound 4: no number, only a limit; the forecaster's own chance of this, stated with the estimate: 85%; the middle value is on the limit's open side.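

In this assay, among the compounds shown here, compound 1 and compound 4 both give only limits, so no step between them can be read. The compounds shown leave open whether hydroxymethyl to 2-hydroxyethyl changes the read-out at all, and where any of their actual values lies.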